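Oxime ether series: chloro in place of 2-methylphenoxy

The source may hold more compounds than are shown below. What is called first, only, known or untested is meant among the compounds shown, and "the series" means these compounds.

Measured so far in a functional assay on PANC-1 cells (Homo sapiens) for inhibition, read by MTT assay, with a stated time of 48 h; on this read-out lower numbers stand for stronger inhibition and higher numbers for weaker inhibition:
- compound 1 `Cc1ccc(Oc2c(/C=N/OCc3snnc3C)c(C)nn2C)cc1` gives > 50000 nM, a limit of the assay
- compound 2 `Cc1nnsc1CO/N=C/c1c(C)nn(C)c1Oc1ccc(OC(F)(F)F)cc1` gives > 50000 nM, a limit of the assay
- compound 3 `CCCc1nnsc1CO/N=C/c1c(C)nn(C)c1Oc1ccccc1C` gives > 50000 nM, a limit of the assay

None of the three values is a number; each is only the assay limit, and all three share it: the limit of > 50000 nM in this assay, at which 3 of the 3 values shown sit. Compound 3 therefore stands at the limit with no number of its own. For the measured compounds named here, the single step between measured compounds, a step that the two limits leave unreadable from compound 1 to compound 2, is unreadable since both of its ends are limits, so the series so far contains no step of readable size.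

Compound 4 `CCCc1nnsc1CO/N=C/c1c(C)nn(C)c1Cl` differs from compound 3 by chloro in place of 2-methylphenoxy on an aromatic carbon. Going by the values given here, no measured step touches this change, and the only computed step offers no size, so the expected step of a number no higher from compound 3 to compound 4 (the limit leaves the size open) rests on no measured evidence; nothing points to a shift beyond the scatter in either direction. Compound 4 is estimated at 50000 nM, within a range from 20000 nM to 200000 nM, and is most likely to be reported as a limit again.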

Compound 4, half-maximal inhibitory concentration: > 50000 nM
Compound 4 ended at the assay's limit; the forecaster's own chance of this, stated with the estimate: 80%; the middle value sits exactly at the limit.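

The step from compound 3 to compound 4 cannot be read, as both of its ends are limits of the assay, not numbers: the limit of > 50000 nM in this assay, at which 4 of the 4 values shown sit.

The compounds shown leave open whether any change to the shared core gives a measurable value in this assay, and how chloro and 2-methylphenoxy truly compare.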